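Methylthio series: thiophen-3-yl in place of ethynyl

The source may report more compounds than this note shows. Statements on the series, on what has been measured and on what is new or still open speak of the compounds shown alone.

Compound 1 `COc1ncnc2c1c(-c1ccsc1)cn2[C@@H]1O[C@H](CO)[C@@H](O)[C@H]1O`: 3350 nM
Compound 2 `CN(C)c1ncnc2c1c(-c1ccsc1)cn2[C@@H]1O[C@H](CO)[C@@H](O)[C@H]1O`: > 15000 nM
Compound 3 `C#Cc1cn([C@@H]2O[C@H](CO)[C@@H](O)[C@H]2O)c2ncnc(SC)c12`: 110 nM

In a functional assay on HeLa S3 cells (Homo sapiens) for antiproliferative activity, read by XTT assay, with a stated time of 72 h (a higher number here means a weaker inhibitor, a lower number a stronger inhibitor), compound 3 gives the lowest of the two numbers shown, the nearest being compound 1 at 3350 nM. The value of compound 2 in this assay is a limit (the limit of > 15000 nM in this assay, at which 1 of the 3 values shown sits). Among the compounds with values here, the one measured step, an at least 4.4-fold higher number from compound 1 to compound 2 (0.65 log units; beyond the scatter), concerns the group on the six-membered ring and does not touch the change at hand. Compound 4 `CSc1ncnc2c1c(-c1ccsc1)cn2[C@@H]1O[C@H](CO)[C@@H](O)[C@H]1O` differs from compound 3 by thiophen-3-yl in place of ethynyl on an aromatic carbon. Within the data shown here, no measured step bears directly on it; compound 1, which carries the thiophen-3-yl group, sits well above compound 3, so a weakening step is expected. Compound 4 is expected at 800 nM, range 200 nM to 3500 nM, a step of a 7.3-fold higher number from compound 3 to compound 4 (0.86 log units; beyond the scatter).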

Compound 4, half-maximal inhibitory concentration: > 20000 nM
Compound 4 gave a limit, no number (the forecaster's own chance of this, stated with the estimate: 5%); middle value at least 25-fold (1.39 log units) away from the limit.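

In this assay compound 4 gives only a limit, > 20000 nM. Thiophen-3-yl in place of ethynyl on this aromatic carbon is a large loss in the methylthio series, an at least 180-fold higher number from compound 3 to compound 4 (2.25 log units; beyond the scatter), the first direct reading of this change. With thiophen-3-yl held, methylsulfanyl in place of methoxy brings no recovery, an at least 5.9-fold higher number from compound 1 to compound 4 (0.77 log units; beyond the scatter), the step from compound 2 to compound 4 cannot be read, and nothing measured here accounts for the loss.

Open, on these data alone, is whether a nitrile or a propynyl chain at this carbon would hold the value of compound 3. Also open, as far as these compounds go, is whether ethynyl paired with methoxy or dimethylamino on the shared core behaves like compound 3.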